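The compounds below may be only part of what the source reports. "The series", "measured", "known", "first", "only" and "open" are said of these compounds alone.

Measured so far in an ADME assay on MT4 cells (Homo sapiens) for cytotoxicity, read by MTT assay; a lower number here means that less compound is tolerated, a higher number that more compound is tolerated:

Compound 1 `Cc1ccc(N(C(=O)c2cccc(C)c2)C(=S)OCCN2C(=O)c3ccccc3C2=O)cc1`: > 100000 nM
Compound 2 `Cc1ccc(N(C(=O)c2ccc(F)cc2F)C(=S)OCCN2C(=O)c3ccccc3C2=O)cc1`: 20000 nM

The entry for compound 1, > 100000 nM, is a limit of the assay and not a number. Compound 2, at 20000 nM, thus holds the only actual number shown in this assay.

Compound 3 `Cc1ccc(N(C(=O)c2cc(F)ccc2F)C(=S)OCCN2C(=O)c3ccccc3C2=O)cc1` has not yet been measured. It differs from compound 2 as follows: 2,5-difluorophenyl in place of 2,4-difluorophenyl on a carbonyl carbon. The two have the same atoms, joined differently, with 2,5-difluorophenyl in place of 2,4-difluorophenyl on a carbonyl carbon.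

For the measured compounds named here, the one measured step, an at least 5.0-fold lower number from compound 1 to compound 2 (0.69 log units; beyond the scatter), lies beyond the scatter, but it exchanged 3-methylphenyl for 2,4-difluorophenyl, which is a different change. Going by the values given here, no measured step covers an exchange between the two difluorophenyl groups. With compound 2 at 20000 nM as the anchor, the expected step, a 1.3-fold higher number from compound 2 to compound 3 (0.10 log units; within the scatter), is estimated to stay within the usual scatter, with no firm direction. For compound 3 the estimated half-maximal cytotoxic concentration is 25000 nM, with an expected range from 9000 nM to 70000 nM.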

Compound 3, half-maximal cytotoxic concentration: 62000 nM
Estimate against measurement, compound 3: 2.5-fold (0.39 log units) below; low and high end bracket the measured number.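

In this assay, 2,5-difluorophenyl in place of 2,4-difluorophenyl, with the same atoms joined differently, gives a 3.1-fold higher number from compound 2 to compound 3 (0.49 log units; beyond the scatter). This place on the carbonyl carbon therefore responds to the arrangement of the two fluorines on the ring, and not only to the exchange of 3-methylphenyl for a difluorophenyl group that the earlier pair covered. The comparison with 3-methylphenyl gives an at least 1.6-fold lower number from compound 1 to compound 3 (0.20 log units; that floor lies within the scatter), and this floor rests on a limit of the assay and not on a number, so it does not separate the two groups: the limit of > 100000 nM in this assay, at which 1 of the 3 values shown sits.

On these data alone, whether 2,6-difluorophenyl, a single fluorine or a chlorine at this place would fall nearer compound 2 or compound 3 stays open. Also open, as far as these compounds go, is whether the gap between the two difluorophenyl groups would persist with a longer chain elsewhere in the shared core.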